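From difluoromethyl to 1,1-difluoroethyl on the shared core

The source may report more compounds than this note shows. Statements on the series, on what has been measured and on what is new or still open speak of the compounds shown alone.

In an in vitro ADME assay on microsomes from liver (Simiiformes) (a lower number here means that the compound disappears faster, a higher number that the compound lasts longer), compound 1 `Cc1cc(CCCOc2c(C)cc(-c3noc(C(N)=O)n3)cc2C)on1` gives 2.3 h and compound 2 `Cc1cc(CCCOc2c(C)cc(-c3noc(C(F)F)n3)cc2C)on1` gives 1.42 h, so these two stand within the scatter of each other. Compound 3 `Cc1cc(CCCOc2c(C)cc(-c3noc(C(C)(F)F)n3)cc2C)on1` differs from compound 2 in one place: methyl in place of hydrogen on a saturated chain carbon bound to an aromatic carbon and two fluorine atoms, which turns difluoromethyl into 1,1-difluoroethyl. Going by the values given here, the only measured step at this place is a 1.6-fold lower number from compound 1 to compound 2 (0.21 log units; within the scatter), and it exchanges a different group, so it offers limited guidance. No step beyond the scatter is therefore expected in this assay. The estimated change is a 1.1-fold higher number from compound 2 to compound 3 (0.02 log units; within the scatter). For compound 3 the expected half-life is 1.5 h, with an estimated range of 0.8 h to 2.8 h.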

Compound 3, half-life: 1.1 h
Compound 3: middle estimate off by 1.4-fold (0.13 log units), on the high side, and the stated range covers the measured number.
By their numbers in this assay, from the lowest: compounds 3, 2 and 1 (each within the scatter of the next, the first and the last beyond it).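

With methyl in place of hydrogen on the saturated chain carbon, the half-life stays within the scatter in this assay (a 1.3-fold lower number from compound 2 to compound 3 (0.11 log units; within the scatter)). Going by these compounds alone, the step with 1,1-difluoroethyl in place of carbamoyl, by contrast, is the first here to pass beyond the scatter, although only modestly (a 2.1-fold lower number from compound 1 to compound 3 (0.32 log units; beyond the scatter)). No measurement at hand bears on the cause of either step.

The compounds shown leave open how trifluoromethyl or a longer chain at this place would read in this assay (for instance 1,1-difluoropropyl). They also leave open how a carboxylic acid would compare with carbamoyl.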